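Cyclopropyl for ethyl on the core of compound 1

The source may hold more compounds than are shown below. What is called first, only, known or untested is meant among the compounds shown, and "the series" means these compounds.

Measured compounds in a functional assay on CHO cells for antagonist activity at Orexin/Hypocretin receptor type 1 (Homo sapiens), read by FLIPR and calcium flux; on this read-out lower numbers stand for stronger inhibition and higher numbers for weaker inhibition:
Compound 1 `CCc1nc(Cl)c2n1CCN([C@@H](C(=O)NC)c1ccccc1)[C@H]2CCc1cccc(C(F)(F)F)c1` gives 72 nM.
Compound 2 `CCc1nc(Cl)c2n1CCN([C@@H](C(=O)NC)c1ccccc1)[C@H]2COc1cccc(C(F)(F)F)c1` gives 312 nM.
Compound 3 `CCc1nc(Cl)c2n1CCN([C@@H](C(=O)NC)c1ccccc1)[C@H]2CCc1ccc(C(F)(F)F)c(F)c1F` gives 17 nM.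

Compound 1 stands second highest of the three numbers in this assay , with compound 3 nearest and compound 2 furthest from it. Both measured steps from compound 1 leave the shared core untouched and alter only the side chain: a 4.3-fold higher number from compound 1 to compound 2 (0.64 log units; beyond the scatter), and a 4.2-fold lower number from compound 1 to compound 3 (0.63 log units; beyond the scatter). Each lies beyond the scatter, yet neither touches the part of the core changed in the new compound.

Compound 4 `CNC(=O)[C@@H](c1ccccc1)N1CCn2c(C3CC3)nc(Cl)c2[C@@H]1CCc1cccc(C(F)(F)F)c1` differs from compound 1 by cyclopropyl in place of ethyl on an aromatic carbon. Within the data shown here, no measured pair shows what a change at this position does in this assay , so the two side-chain steps give no direct guide to its size or direction. In the absence of any bearing step, the expectation is for no step beyond the scatter: compound 4 is estimated to give 72 nM, with a range from 25 nM to 210 nM. This estimate corresponds to no change at the digits printed from compound 1 to compound 4 (within the scatter), a step expected to stay within the usual scatter, though the range is kept wide because nothing measured speaks to this position.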

Compound 4, half-maximal inhibitory concentration: 91 nM
Estimate against measurement, compound 4: 1.3-fold (0.10 log units) below; the measured number falls inside the stated range.
By their numbers in this assay, from the lowest: compound 3; then compounds 1 and 4 (each within the scatter of the next); then compound 2.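

In this assay, among these compounds, the first measured change on the aromatic carbon between two ring nitrogen atoms gives a 1.3-fold higher number from compound 1 to compound 4 (0.10 log units; within the scatter), so cyclopropyl and ethyl cannot be told apart at this position on this read-out. The earlier steps shown here all lay in the side chain, whereas this pair shows that, with the 3-(trifluoromethyl)phenyl side chain of compound 1, a three-membered non-aromatic ring of carbon only can stand at this position of the shared core without a step beyond the scatter. Nothing in hand explains why the two groups read alike.

From the compounds shown here alone, whether the same swap stays within the scatter alongside the 2,3-difluoro-4-(trifluoromethyl)phenyl side chain of compound 3 or the 3-(trifluoromethyl)phenoxy side chain of compound 2 remains open. The compounds shown also leave open how far this position tolerates other groups, such as a longer chain like n-butyl, an amine or a carboxylic acid, since ethyl and cyclopropyl are the only two groups compared here and both contain carbon alone.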